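Aminophenyl position in a seven-membered ring series

A few compounds are considered here, and "the series" means these few. Any claim that something is new, unique, unknown or untested is made for them only; others in the source may bear on it.

Two compounds of this series have been run in a functional assay on the whole organism with Mus musculus as the target; a higher number here means that more compound is needed for the effect, a lower number that less compound is needed. Compound 1 `COc1cc2c(cc1OC)C(c1ccc([N+](=O)[O-])cc1)=NNC(=O)C2` carries a nitrophenyl group and a carbonyl in its core; in this assay compound 1 reaches only the limit > 120 umol/kg, and this is a limit of the assay rather than a measured number. Compound 2 `COc1cc2c(cc1OC)C(c1ccc(N)cc1)=NN=C(S)C2` carries a 4-aminophenyl group and a sulfanyl group; in this assay compound 2 gives 3.3 umol/kg. For the measured compounds named here, compound 2 thus holds the only numerical value so far, the other entry being a limit (the limit of > 120 umol/kg in this assay, at which 1 of the 2 values shown sits).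

Compound 3 `COc1cc2c(cc1OC)C(c1cccc(N)c1)=NN=C(S)C2` is not yet measured. It differs from compound 2 in one place: 3-aminophenyl in place of 4-aminophenyl on a carbon with a double bond to nitrogen. Going by the values given here, no measured step of this kind exists, so the size of the step can only be expected. Moving the amino group around the ring is expected to shift the dose modestly rather than to abolish activity; the step from compound 2 to compound 3 is expected to be a 1.8-fold higher number from compound 2 to compound 3 (0.26 log units; within the scatter), toward a somewhat higher dose. Compound 3 is therefore estimated at 6 umol/kg, with a range from 2 umol/kg to 20 umol/kg.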

Compound 3, dose for half-maximal effect: 9.1 umol/kg
Compound 3: the middle estimate sits 1.5-fold (0.18 log units) below what was measured; the range from low to high includes it.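

Moving the amino group, 3-aminophenyl in place of 4-aminophenyl on the carbon with a double bond to nitrogen, gives the first one-place step in this series: in this assay it is a 2.8-fold higher number from compound 2 to compound 3 (0.44 log units; beyond the scatter). The position is therefore sensitive to where the amino group sits on the phenyl ring, with 4-aminophenyl holding the lower number of this pair, although the 3-aminophenyl group still gives a numerical dose rather than a limit. Nothing in the data shown accounts for the size or direction of this step.

Compound 1 stands at > 120 umol/kg, a limit of the assay, and differs from compound 2 in more than one place, so it gives no separate reading of the nitrophenyl group or the carbonyl. Open at this position are whether the amino group itself is needed and whether a hydroxyl or a dimethylamino group on the phenyl ring would keep a dose in the same range.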